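This account rests on a few compounds, and the source may have more. Where it says the series, first, only, none or still open, it means among the compounds named here.

Working notes on the series. Compound 1 `O=C1/C(=C\c2ccc(O)cc2)c2ccccc2N1c1c(Cl)cccc1Cl` and compound 2 `O=C1/C(=C\c2ccccc2[N+](=O)[O-])c2ccccc2N1c1c(Cl)cccc1Cl` share one core and differ only in the aryl group on the exocyclic double bond. In a functional assay on B16-F10 cells (Homo sapiens) for cytotoxicity against B16-F10 (Mus musculus), read by MTT assay, with a stated time of 72 h (a higher number here means that more compound is needed for the effect, a lower number that less compound is needed), compound 1 gives 33 ug/mL. For compound 2 the same assay records only a limit, > 100 ug/mL. Compound 2 thus stands at the edge of the measured range, and the step of an at least 3.0-fold higher number from compound 1 to compound 2 (0.48 log units; beyond the scatter) rests on the limit of > 100 ug/mL in this assay, at which 1 of the 2 values shown sits, rather than on a number. Compound 3 `O=C1/C(=C\c2ccccc2Cl)c2ccccc2N1c1c(Cl)cccc1Cl` is not yet measured; it differs from compound 2 by chloro in place of nitro on an aromatic carbon. Among the measured compounds shown here, the one measured step concerns the exchange of the whole aryl group, not this single swap, so it fixes no direction for this assay. The expected step is an at least 1.6-fold lower number from compound 2 to compound 3 (0.22 log units; that floor lies within the scatter), read as a return towards the region of compound 1. Compound 3 is therefore estimated at 60 ug/mL, with a range from 20 ug/mL to 150 ug/mL.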

Compound 3, concentration for half-maximal effect: 39 ug/mL
Estimate against measurement, compound 3: 1.5-fold (0.19 log units) above; the measured number falls inside the stated range.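

In this assay, the exchange of nitro for chloro on the aromatic carbon, with the rest of compound 2 unchanged, gives an at least 2.5-fold lower number from compound 2 to compound 3 (0.40 log units; beyond the scatter); the earlier step replaced the whole aryl group and could not isolate this swap. For compound 2 the value is a limit, so this step is only a floor: the limit of > 100 ug/mL in this assay, at which 1 of the 3 values shown sits. Among the compounds shown here, with a 1.2-fold higher number from compound 1 to compound 3 (0.07 log units; within the scatter), the 2-chlorophenyl and 4-hydroxyphenyl groups on the exocyclic double bond are not separated in this assay, which leaves 2-nitrophenyl as the only aryl group of the three that stands apart.

On these data alone, whether an amine or a methoxy group on the same aromatic carbon would track chloro or nitro remains open. Also open, as far as these compounds go, is whether chloro would hold this level on another carbon of the ring.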